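The compounds below may be only part of what the source reports. "The series", "measured", "known", "first", "only" and "open" are said of these compounds alone.

Compound 2 `Oc1ccc(O)c(-c2cc(-c3ccccc3)nn2-c2ccccc2)c1` carries two hydroxyl groups on one ring and an unsubstituted phenyl on the other side. In a functional assay on cells (Melanoma cell, Homo sapiens) for cytotoxicity, read by sulforhodamine B assay, with a stated time of 48 h (on this read-out higher numbers stand for weaker inhibition of growth and lower numbers for stronger inhibition of growth), compound 2 gives 63900 nM, the highest of the three numbers measured, though every gap to the others is within the scatter. Compound 3 `Oc1ccc(O)c(-c2cc(-c3ccc(Cl)cc3)nn2-c2ccccc2)c1` gives 32500 nM in this assay, and the step of a 2.0-fold lower number from compound 2 to compound 3 (0.29 log units; within the scatter) shows how little a chloro for hydrogen changed the read-out. Compound 1 `COc1ccc(OC)c(-c2cc(-c3ccccc3)nn2-c2ccc(S(N)(=O)=O)cc2)c1` gives 40800 nM in this assay; it bears the sulfamoyl but also two methoxy groups instead of hydroxyls, so its value and that of compound 2 can only be set side by side, not read as a single step. Compound 4 `NS(=O)(=O)c1ccc(-n2nc(-c3ccccc3)cc2-c2cc(O)ccc2O)cc1` differs from compound 2 by sulfamoyl in place of hydrogen on an aromatic carbon. For the measured compounds named here, no measured step isolates this change. Going by the values given here, since the only comparisons available, compound 1 against compound 2 and the step from compound 2 to compound 3, all stay within the scatter, compound 4 is expected to show a step of a 1.4-fold lower number from compound 2 to compound 4 (0.15 log units; within the scatter), no larger than the scatter. Compound 4 is therefore estimated at 45000 nM, between 20000 nM and 100000 nM.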

Compound 4, concentration for total growth inhibition: 92000 nM
Beside the measured number, compound 4's estimate is 2.0-fold (0.31 log units) below it, within the range that was stated.
By their numbers in this assay, from the lowest: compounds 3, 1, 2 and 4 (each within the scatter of the next, the first and the last beyond it).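

Sulfamoyl in place of hydrogen, para to a large group, is seen here on its own for the first time, and the step is a 1.4-fold higher number from compound 2 to compound 4 (0.16 log units; within the scatter) in this assay, so at this position the change leaves the number within the usual spread of repeat measurements. With sulfamoyl present in both compounds, 2,5-dihydroxyphenyl in place of 2,5-dimethoxyphenyl gives a 2.3-fold higher number from compound 1 to compound 4 (0.35 log units; beyond the scatter), a modest step but the only one so far beyond the scatter, and it points towards weaker inhibition of growth. Nothing measured here offers an explanation for either step.

From the compounds shown here alone, whether an amine or a carboxylic acid at the same position would read differently from sulfamoyl remains open. Also open, going by these compounds, is whether the hydroxyl-for-methoxy step would be of similar size without the sulfamoyl.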